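Opening a ring: from compound 2 toward compound 4

This account rests on a few compounds, and the source may have more. Where it says the series, first, only, none or still open, it means among the compounds named here.

In an assay for activation of potassium voltage-gated channel subfamily KQT member 1 (Cavia porcellus) (a higher number here means a weaker inhibitor, a lower number a stronger inhibitor), compound 2 `CCCCCCOc1ccc(C(=O)NC2CCC(C)(C)C2)cc1` gives 360 nM, and compound 1 `CCCCCCOc1ccc(C(=O)NCC2CCCC(C)(C)C2)cc1` gives 370 nM, the two numbers lying within the usual scatter of each other. Compound 3 `CCCCCCOc1ccc(C(=O)NCC2CCCC2(C)C)cc1` has been measured more than once in this assay, giving 710 nM; 160 nM (2 entries); the spread between its entries, (the several entries of compound 3 in this assay, 710 nM; 160 nM (2 entries)), shows how far repeated measurements can differ here. Among the measured compounds shown here, no single change between two measured compounds has been recorded, so no measured step is available. Compound 4 `CCCCCCOc1ccc(C(=O)NCCC(C)(C)C)cc1` differs from compound 2 by 3,3-dimethylbutyl in place of 3,3-dimethylcyclopentyl on an amide-type nitrogen. For this change, the step from compound 2 to compound 4 is expected to be small, a 1.4-fold higher number from compound 2 to compound 4 (0.14 log units; within the scatter), at most a modest move toward a weaker number. Compound 4 is therefore estimated at 500 nM, with a range from 180 nM to 1400 nM.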

Compound 4, half-maximal inhibitory concentration: 250 nM
Beside the measured number, compound 4's estimate is 2.0-fold (0.30 log units) above it, within the range that was stated.
By their numbers in this assay, from the lowest: compounds 4, 2 and 1 (each within the scatter of the next).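

In this assay, the ring of compound 2 proves dispensable at this amide-type nitrogen, with a 1.4-fold lower number from compound 2 to compound 4 (0.16 log units; within the scatter) for the open 3,3-dimethylbutyl group. The larger ring of compound 1 gives the same reading, with a 1.5-fold lower number from compound 1 to compound 4 (0.17 log units; within the scatter) on passing to neopentyl on the saturated chain carbon. Repeated entries differ by more than either step: the several entries of compound 3 in this assay, 710 nM; 160 nM (2 entries).

Going by these compounds, it remains open whether a plain n-butyl chain without the two methyl groups would hold the number. The same is true of a longer chain, or of an amine at the chain end.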